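This account rests on a few compounds, and the source may have more. Where it says the series, first, only, none or still open, it means among the compounds named here.

Measured compounds in a functional assay for inhibition, read by spectrophotometry, with a stated time of 30 min, tested at 1 uM; on this read-out higher numbers stand for more inhibition at the one concentration tested (going by the name of the read-out) and lower numbers for less inhibition:

compound 1 `CCCNC(=C\C(=O)/C=C/c1ccc(O)c(OC)c1)/C=C/c1ccc(O)c(OC)c1` — 0.1%
compound 2 `C=CCNC(=C\C(=O)/C=C/c1ccc(O)c(OC)c1)/C=C/c1ccc(O)c(OC)c1` — 0.1%
compound 3 `CCC(C)NC(=C\C(=O)/C=C/c1ccc(O)cc1)/C=C/c1ccc(O)cc1` — 0.03%

Compound 2 stands level with compound 1 at the digits given; compound 3, which carries the different amine substituent and lacks the methoxy groups on both aryl rings, returns a number within the scatter of both. None of the three can be told apart in this assay, and none shows inhibition that rises above the scatter.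

Compound 4 `COc1cc(/C=C/C(=O)/C=C(/C=C/c2ccc(O)c(OC)c2)NCC(C)C)ccc1O` is reached from compound 2 by one change on the amine substituent: isopropyl in place of vinyl on a saturated chain carbon bound to an amine nitrogen.

Within the data shown here, the one measured step that bears on this change is the step on the same saturated chain carbon bound to the amine nitrogen, no change at the digits printed from compound 1 to compound 2 (within the scatter), which left the read-out unmoved. Among the measured compounds shown here, the only other measured compound, compound 3, sits within the scatter as well, so the three numbers give no sign that the amine substituent shifts this assay at all.

For compound 4 the expected step is therefore no change at the digits printed from compound 2 to compound 4 (within the scatter), that is, none beyond the scatter. The estimate for compound 4 is 0.1%, with a range from 0% to 8%.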

Compound 4, a percentage reported as inhibition, at one concentration (the size of the read-out at that concentration, not a potency): 0.09%
Compound 4: the middle estimate sits 0 percentage points above what was measured; the range from low to high includes it.
By their numbers in this assay, from the lowest: compounds 3, 4, 1 and 2 (each within the scatter of the next).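

In this assay, the branched isobutylamino group now joins the allylamino and propylamino groups on the shared core, and the swap of vinyl for isopropyl on a saturated chain carbon bound to an amine nitrogen gives a number 0 percentage points lower from compound 2 to compound 4 (within the scatter) at this site. Branching is the feature the earlier one-place step did not cover, and methyl in place of hydrogen on a saturated chain carbon bound to two saturated chain carbons gives a number 0 percentage points lower from compound 1 to compound 4 (within the scatter) in the same read-out, so neither removing the double bond nor adding a branch separates these compounds, and all three one-place neighbours remain indistinguishable with no inhibition above the scatter. Nothing further is at hand that could account for this flat read-out at the amine substituent.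

On these data alone, whether any substituent on this nitrogen can move the read-out at all remains open, since these three chains are all small hydrocarbon groups and a benzyl group, a chain ending in a carboxylic acid or a much longer chain would test a wider range. With only one tested concentration, the compounds shown also leave open whether the series would separate at a higher concentration in this assay or stays flat there too.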